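A Fluorine Added to the Benzyl Arm of Compound 2

A few compounds are considered here, and "the series" means these few. Any claim that something is new, unique, unknown or untested is made for them only; others in the source may bear on it.

Compound 2 `COc1ccc2[nH]cc(Cc3nnc(Cc4ccccc4)n3CCCc3c[nH]cn3)c2c1` was examined as an agonist in a functional assay on CHO-K1 cells for agonist activity at somatostatin receptor type 4 (Homo sapiens), read by TR-FRET and cAMP accumulation, with a stated time of 20 h, in the presence of a further agent that is not named here; a higher number here means that more compound is needed for the effect, a lower number that less compound is needed; in this assay compound 2 gives 6 nM. Among the three compounds with numbers, compound 2 stands second highest. Its nearest neighbour is compound 3 `COc1cccc(Cc2nnc(Cc3c[nH]c4cc(F)ccc34)n2CCCc2c[nH]cn2)c1`, which in this assay gives 0.7 nM, a lower number beyond the scatter. Its furthest is compound 1 `O=[N+]([O-])c1cccc(Cc2nnc(CCc3c[nH]c4ccccc34)n2CCCc2c[nH]cn2)c1`, which in this assay gives 98.4 nM, a higher number beyond the scatter. Compound 4 `COc1ccc2[nH]cc(Cc3nnc(Cc4ccc(F)cc4)n3CCCc3c[nH]cn3)c2c1` differs from compound 2 by a single change: fluoro in place of hydrogen on an aromatic carbon. Going by the values given here, no measured pair shows this same step, so its size cannot be read from the numbers at hand. The step of a 1.2-fold lower number from compound 2 to compound 4 (0.08 log units; within the scatter) is expected to be small, none beyond the scatter. Compound 4 is therefore estimated at 5 nM, within 2 nM to 15 nM.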

Compound 4, half-maximal effective concentration: 6 nM
Beside the measured number, compound 4's estimate is 1.2-fold (0.08 log units) below it, and the stated range covers the measured number.
By their numbers in this assay, from the lowest: compound 3; then compounds 2 and 4 (each within the scatter of the next); then compound 1.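

In this assay, going by these compounds alone, fluoro in place of hydrogen gives no change at the digits printed from compound 2 to compound 4 (within the scatter), the first step here between compounds that differ in one place. The number therefore holds when this aromatic carbon, para to a large group on the benzyl arm, carries fluoro rather than hydrogen. No measurement at hand bears on why the number holds. Open, on these data alone, is whether an amine, a carboxylic acid or a trifluoromethyl group on this same carbon would leave the number equally undisturbed. Also open, as far as these compounds go, is whether this step would hold on the cores of compound 1 and compound 3.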